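The source may report more compounds than this note shows. Statements on the series, on what has been measured and on what is new or still open speak of the compounds shown alone.

Measured compounds:
Compound 1 `CO[C@H]1CC[C@H](N2CC(=O)Nc3ncc(-c4ccc(C(C)(C)O)nc4)nc32)CC1` gives 35800 ng.h/mL in an ADME assay on the whole organism for pharmacokinetics, with Rattus norvegicus as the target, at a dose of 5 mg/kg by the oral route; on this read-out lower numbers stand for lower exposure and higher numbers for higher exposure at the dose given.
Compound 2 `COCCN1C(=O)CNc2ncc(-c3ccc(C(C)(C)O)nc3)nc21` gives 9960 ng.h/mL.
Compound 3 `CC(C)(O)c1ccc(-c2cnc3c(n2)N(CCC2CCOCC2)C(=O)CN3)cn1` gives 5560 ng.h/mL.

Compound 1 stands highest of the three on this read-out, with compound 2 nearest and compound 3 furthest, both beyond the scatter. Going by the values given here, the only measured step, a 1.8-fold lower number from compound 2 to compound 3 (0.25 log units; within the scatter), concerns a side chain absent from compound 1 and does not bear on the change to compound 4 `CO[C@H]1CC[C@@H](N2CC(=O)Nc3ncc(-c4ccc(C(C)(C)O)nc4)nc32)CC1`. That change is the two compounds have the same atoms and bonds and differ only in configuration as drawn: 2 of 2 stereo elements differ (all stereocentres are inverted: mirror images); a stereocentre at a saturated ring carbon is drawn r in compound 1 and s in compound 4; a stereocentre at a saturated ring carbon is drawn r in compound 1 and s in compound 4. Among the compounds with values here, no measured step informs a change of configuration alone, so no direction can be read from the data. The number for compound 4 is therefore expected near that of compound 1, with a wide range, estimated at 25000 ng.h/mL (range 8000 ng.h/mL to 60000 ng.h/mL), a step of a 1.4-fold lower number from compound 1 to compound 4 (0.16 log units; within the scatter).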

Compound 4, area under the concentration-time curve: 10600 ng.h/mL
Beside the measured number, compound 4's estimate is 2.4-fold (0.37 log units) above it; low and high end bracket the measured number.
By their numbers in this assay, from the lowest: compounds 3, 2 and 4 (each within the scatter of the next); then compound 1.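

In this assay, going by these compounds alone, the saturated ring carrying the methoxy group proves sensitive to configuration, which the earlier compounds could not show: a 3.4-fold lower number from compound 1 to compound 4 (0.53 log units; beyond the scatter). The arrangement drawn in compound 1 is the one giving the higher exposure. With atoms and bonds unchanged, this gap can be traced to configuration alone: the fact that compounds 1 and 4 differ only in the configuration as drawn

As far as these compounds go, whether an amine or a carboxylic acid in place of the methoxy group would keep such a gap between the two configurations remains open. So does the question of whether uptake or removal in the rat produces the gap.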